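Compound 2 to compound 3 near the assay limit

The source may hold more compounds than are shown below. What is called first, only, known or untested is meant among the compounds shown, and "the series" means these compounds.

Among the measured compounds shown here, compound 1 (`CCCCc1oc2ccccc2c1C(=O)c1ccc(OCCCC(=O)N2CCCC2)cc1`) gives 23500 nM in a functional assay on MCF7 cells (Homo sapiens) for antiproliferative activity, read by MTT assay, with a stated time of 24 h (a higher number here means a weaker inhibitor, a lower number a stronger inhibitor), and is the only compound with a true number so far. Compound 2 (`CCCCc1oc2ccccc2c1C(=O)c1ccc(OCCCC(=O)N(C)Cc2ccccc2)cc1`) gives > 50000 nM in this assay and this is a limit of the assay, not a number. Compound 2 therefore rests on the limit of > 50000 nM in this assay, at which 1 of the 2 values shown sits, and nothing firmer.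

Compound 3 (`CCCCc1oc2ccccc2c1C(=O)c1ccc(OCCCC(=O)N[C@H](C)c2ccccc2)cc1`) carries (1-phenylethyl)amino in place of benzyl(methyl)amino on a carbonyl carbon and so gains the amide hydrogen. For the measured compounds named here, the one measured step at this place is an at least 2.1-fold higher number from compound 1 to compound 2 (0.32 log units; beyond the scatter) and it is only a bound. Going by the values given here, no measured step covers the amide hydrogen. A small move toward a lower number in this assay is expected, possibly none beyond the scatter. The estimated step is an at least 1.2-fold lower number from compound 2 to compound 3 (0.09 log units; that floor lies within the scatter) and no larger. For compound 3 the estimate is 40000 nM with 18000 nM to 90000 nM as the expected range.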

Compound 3, half-maximal inhibitory concentration: > 50000 nM
Compound 3 gave a limit, no number; the forecaster's own chance of this, stated with the estimate: 50%; middle value at least 1.2-fold (0.09 log units) from the limit.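

In this assay compound 3 gives > 50000 nM, which is a limit of the assay and not a number. Among the compounds shown here, with (1-phenylethyl)amino in place of pyrrolidin-1-yl on a carbonyl carbon the result is an at least 2.1-fold higher number from compound 1 to compound 3 (0.32 log units; beyond the scatter), so a second replacement of pyrrolidin-1-yl, this one carrying the amide hydrogen, also leaves compound 1 as the only compound with a true number. The step between the two limits cannot be read, so the amide hydrogen has no readable effect here, and the comparison stops at one ceiling: the limit of > 50000 nM in this assay, at which 2 of the 3 values shown sit.

Open, as far as these compounds go, is whether morpholin-4-yl or dimethylamino on this carbonyl carbon, or a free carboxylic acid in place of the amide, would give a true number in this assay. Also open, from the compounds shown here alone, is whether a shorter or longer chain would shift compound 1.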